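Removing a fluoro from an inactive arylidene diketopiperazine

The compounds below may be only part of what the source reports. "The series", "measured", "known", "first", "only" and "open" are said of these compounds alone.

This account follows a single change within a small set of bis-arylidene compounds sharing one core. Compound 1, `C=CCn1c(=O)/c(=C\c2cc(F)ccc2C)[nH]c(=O)/c1=C\c1ccccc1OC`, gives 5600 nM in a functional assay on Huh-7 cells (Homo sapiens) for cytotoxicity, read by CCK-8 assay, with a stated time of 72 h; on this read-out higher numbers stand for weaker inhibition and lower numbers for stronger inhibition. Compound 2, `C=CCn1c(=O)/c(=C\c2ccc(F)c(Br)c2)[nH]c(=O)/c1=C\c1ccccc1OC`, is reported in this assay as "not active" (no number reported), so no number places it on the scale, and without a number there is no way to set a step between compound 1 and compound 2 in this assay. Compound 3, `C=CCn1c(=O)/c(=C\c2cccc(Br)c2)[nH]c(=O)/c1=C\c1ccccc1OC`, differs from compound 2 by hydrogen in place of fluoro on an aromatic carbon, the fluoro leaving an aromatic carbon that is ortho to a bromo group and para to a large group. Because compound 2 stands at "not active" (no number reported) in this assay, neither the size nor the direction of the step to compound 3 can be told from the data, and only a weak response seems likely. Compound 3 is estimated at 15000 nM in this assay, within a range of 4000 nM to 60000 nM.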

Compound 3, half-maximal inhibitory concentration: 2300 nM
The estimate for compound 3 lay 6.5-fold (0.81 log units) above the measured number; the whole stated range lies above it.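

With hydrogen in place of the fluoro, the 3-bromophenyl group brings the series back onto the scale: in this assay compound 3 gives 2300 nM, whereas compound 2 has no number, so the step between those two cannot be read. Compound 3 also goes beyond compound 1, with a 2.4-fold lower number from compound 1 to compound 3 (0.39 log units; beyond the scatter), a modest step that shows a 3-bromophenyl group can carry a lower number than the 5-fluoro-2-methylphenyl group at this place on the shared core. No measurement at hand speaks to the reason for either result.

The compounds shown leave open what an amine or a chloro group on the aromatic carbon that lost the fluoro would give. Going by these compounds alone, they also leave open whether the bromo group itself is needed, as no compound here has an unsubstituted phenyl at this place.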